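The compounds below may be only part of what the source reports. "The series", "measured", "known", "first", "only" and "open" are said of these compounds alone.

Compounds measured in an ADME assay on HEK-293T cells (Homo sapiens) for cytotoxicity, read by luminescence, with a stated time of 24 h (a lower number here means that less compound is tolerated, a higher number that more compound is tolerated), so far. Compound 1 `COc1ccc(Cn2c(C(=O)N3CCCCC3)cc3sccc32)cc1` gives > 100000 nM, a limit of the assay and not a number. Compound 2 `CCCNC(=O)C1CCN(C(=O)c2cc3sccc3n2Cc2ccc(OC)cc2)CC1` gives 18800 nM. Compound 3 `COc1ccc(Cn2c(C(=O)N3CCC(C(=O)NC4CC4)CC3)cc3sccc32)cc1` gives 21400 nM.

Among the two numbers, compound 2 holds the lowest; its nearest neighbour is compound 3, at a 1.1-fold higher number from compound 2 to compound 3 (0.06 log units; within the scatter), within the scatter. Compound 1 sits at the limit (the limit of > 100000 nM in this assay, at which 1 of the 3 values shown sits). The two steps that move beyond the scatter both add a carbamoyl to a saturated ring carbon: an at least 5.3-fold lower number from compound 1 to compound 2 (0.72 log units; beyond the scatter) and an at least 4.6-fold lower number from compound 1 to compound 3 (0.66 log units; beyond the scatter). Swapping the group on the amide-type nitrogen, a 1.1-fold higher number from compound 2 to compound 3 (0.06 log units; within the scatter), leaves the number where it was.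

Compound 4 `CCCNC(=O)C1CCN(C(=O)c2cc3sc(C(=O)c4ccccc4)cc3n2Cc2ccc(OC)cc2)CC1` differs from compound 2 as benzoyl in place of hydrogen on an aromatic carbon. Among the measured compounds shown here, no measured step touches the shared core in this way, so none bears on it directly; the steps seen are all on the piperidine side. With nothing to anchor a direction, the expected step is a 1.6-fold lower number from compound 2 to compound 4 (0.19 log units; within the scatter), a small lowering that stays close to the scatter. Compound 4 is thus estimated at 12000 nM, between 4000 nM and 40000 nM, in this assay.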

Compound 4, half-maximal cytotoxic concentration: > 100000 nM
Compound 4: a limit, no number; the forecaster's own chance of this, stated with the estimate: 10%; middle value at least 8.3-fold (0.92 log units) away from the limit.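

In this assay, among the compounds shown here, the aromatic carbon next to the ring sulfur is the first place on the shared core where a change can be read, and benzoyl there gives an at least 5.3-fold higher number from compound 2 to compound 4 (0.72 log units; beyond the scatter). For the compounds shown here, the earlier steps all lay on the piperidine side and either lowered the number or left it in place, so this is the first step that raises it, with the propylcarbamoyl group still present. The value of compound 4 is a limit of the assay and not a number, so the full size of this step stays unknown: the limit of > 100000 nM in this assay, at which 2 of the 4 values shown sit.

Going by these compounds, whether this rise needs the whole benzoyl group stays open, as a methyl, an amine or a carboxylic acid on the same carbon would test. Also open, on these data alone, is whether benzoyl there gives the same rise alongside the cyclopropylcarbamoyl group of compound 3.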